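Swapping 4-fluorobenzyl for 3-chlorobenzyl on a shared core

The source may report more compounds than this note shows. Statements on the series, on what has been measured and on what is new or still open speak of the compounds shown alone.

- Compound 1 `CCOC(=O)COn1c(-c2cccc(C#N)c2)nc(C)c1C(=O)OCC`: 6800 nM
- Compound 2 `CCOC(=O)c1c(C)nc(-c2cccc(C#N)c2)n1OCc1ccc(F)cc1`: 5880 nM

Within the data shown here, in a functional assay on a cell-free system (plasma, Oryctolagus cuniculus) for inhibition, with stated times of 5 min, 1 min and 6 min (a higher number here means a weaker inhibitor, a lower number a stronger inhibitor), compound 2, at 5880 nM, stands level with compound 1, since the only measured step is a 1.2-fold lower number from compound 1 to compound 2 (0.06 log units; within the scatter). Compound 3 `CCOC(=O)c1c(C)nc(-c2cccc(C#N)c2)n1OCc1cccc(Cl)c1` has 3-chlorophenyl in place of 4-fluorophenyl on a saturated chain carbon bound to an oxygen on an aromatic ring. Among the measured compounds shown here, that measured step changed the group at this same place, and no measured compound carries the new group, so the evidence is thin. The estimated change is a 1.2-fold lower number from compound 2 to compound 3 (0.07 log units; within the scatter), so none beyond the scatter is expected. For compound 3 the expected value is 5000 nM, with an estimated range of 2000 nM to 12000 nM.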

Compound 3, half-maximal inhibitory concentration: 19400 nM
Estimate against measurement, compound 3: 3.9-fold (0.59 log units) below, and the stated range ends below it.
By their numbers in this assay, from the lowest: compounds 2 and 1 (each within the scatter of the next); then compound 3.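

This position is not indifferent to the group it carries. In this assay, 3-chlorophenyl weakens inhibition relative to 4-fluorophenyl (a 3.3-fold higher number from compound 2 to compound 3 (0.52 log units; beyond the scatter)) and relative to ethoxycarbonyl (a 2.9-fold higher number from compound 1 to compound 3 (0.46 log units; beyond the scatter)), even though those two earlier groups stood level. Nothing available offers an explanation for this loss. The change swaps the halogen and also moves it on the ring, so the compounds shown cannot separate those two effects. Going by these compounds, how an unsubstituted phenyl or an amine on this chain carbon would behave also remains open.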